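A Mirror Change at One Chain Carbon

The compounds below may be only part of what the source reports. "The series", "measured", "known", "first", "only" and "open" are said of these compounds alone.

The measured compounds in a functional assay on HeLa cells (Homo sapiens) for cytotoxicity, read by WST assay, with a stated time of 48 h; on this read-out lower numbers stand for stronger inhibition and higher numbers for weaker inhibition:
Compound 1 `COC[C@H](C)[C@H](C)C(c1ccc(O)c(OC)c1)c1ccc(O)c(OC)c1` gives 72000 nM.
Compound 2 `COc1cc(C(c2ccc(O)c(OC)c2)[C@H](C)[C@H](C)CO)ccc1O` gives > 100000 nM, which is a limit of the assay and not a number.
Compound 3 `COc1cc(C(c2ccc(O)c(OC)c2)[C@H](C)[C@@H](C)CF)ccc1O` gives 34000 nM.

Among these, compound 1 carries the highest of the two real numbers; its nearest neighbour is compound 3, reached by a 2.1-fold lower number from compound 1 to compound 3 (0.33 log units; beyond the scatter). The remaining value, that of compound 2, is a limit (the limit of > 100000 nM in this assay, at which 1 of the 3 values shown sits).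

Compound 4 `COC[C@@H](C)[C@H](C)C(c1ccc(O)c(OC)c1)c1ccc(O)c(OC)c1` differs from compound 1 only in configuration: the two compounds have the same atoms and bonds and differ only in configuration as drawn: 1 of 2 stereo elements differ; a stereocentre at a saturated chain carbon is drawn R in compound 1 and S in compound 4. For the measured compounds named here, none of the measured steps changes a stereocentre alone. The steps of an at least 1.3-fold higher number from compound 1 to compound 2 (0.14 log units; that floor lies within the scatter), an at least 2.9-fold lower number from compound 2 to compound 3 (0.46 log units; beyond the scatter) and a 2.1-fold lower number from compound 1 to compound 3 (0.33 log units; beyond the scatter) all exchange one group for another on the chain, and even these stay modest. A change of drawn configuration at a single chain carbon, with the same atoms and bonds, gives no ground to expect a step beyond the scatter in either direction. Compound 4 is therefore estimated at 72000 nM, within 30000 nM to 150000 nM, which means an expected step of no change at the digits printed from compound 1 to compound 4 (within the scatter).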

Compound 4, half-maximal inhibitory concentration: 58000 nM
Beside the measured number, compound 4's estimate is 1.2-fold (0.09 log units) above it; the measured number falls inside the stated range.
By their numbers in this assay, from the lowest: compounds 3, 4 and 1 (each within the scatter of the next, the first and the last beyond it). At a limit, above all of these: compound 2.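

In this assay, for the compounds shown here, the mirror change at this chain carbon stays within the scatter, a 1.2-fold lower number from compound 1 to compound 4 (0.09 log units; within the scatter), so this pair gives the first direct reading of configuration alone, and that reading shows no clear effect: the fact that compounds 1 and 4 differ only in the configuration as drawn. The step involving the fluoromethyl compound is also small, a 1.7-fold higher number from compound 3 to compound 4 (0.23 log units; within the scatter). Compound 2 holds a limit and not a number, so an at least 1.7-fold lower number from compound 2 to compound 4 (0.23 log units; that floor lies within the scatter) gives only a floor: the limit of > 100000 nM in this assay, at which 1 of the 4 values shown sits.

From the compounds shown here alone, whether the same mirror change would stay this small with a hydroxymethyl or fluoromethyl end on the chain, or at the other stereocentre of the chain, remains open. So does how an aminomethyl end, a carboxylic acid or a longer chain at this position would read in this assay.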